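This account rests on a few compounds, and the source may have more. Where it says the series, first, only, none or still open, it means among the compounds named here.

Working notes on the series. Three compounds have numbers in a functional assay on HeLa cells (Homo sapiens) for cytotoxicity, read by MTT assay, with a stated time of 72 h; on this read-out higher numbers stand for weaker inhibition and lower numbers for stronger inhibition. Compound 1 `Cc1cc(S(=O)(=O)/N=C(\N)n2nccc2-c2ccccc2)c(SCc2ccc(Cl)cc2)cc1Cl` gives 3000 nM. Compound 2 `Cc1cc(-c2ccccc2)n(/C(N)=N/S(=O)(=O)c2cc(C)c(Cl)cc2SCc2ccccc2)n1` gives 5000 nM. Compound 3 `Cc1cc(-c2ccccc2)n(/C(N)=N/S(=O)(=O)c2cc(C)c(Cl)cc2SCc2cccc(C(F)(F)F)c2)n1` gives 98000 nM, the highest of the three, so compound 3 stands as the weakest inhibitor in this set; compound 2 is nearest to it and compound 1 furthest, both with far lower numbers. Within the data shown here, the one single-point step recorded, a 20-fold higher number from compound 2 to compound 3 (1.29 log units; beyond the scatter), is large and runs toward weaker inhibition.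

Compound 4 `Cc1cc(-c2ccccc2)n(/C(N)=N/S(=O)(=O)c2cc(C)c(Cl)cc2SCc2ccc(Cl)cc2)n1` has not yet been measured. Its difference from compound 3 is 4-chlorophenyl in place of 3-(trifluoromethyl)phenyl on a saturated chain carbon bound to a sulfur. The step from compound 2 to compound 3 bears directly on this, since compound 4 removes the same trifluoromethyl that compound 3 carries and replaces the group with 4-chlorophenyl. Compound 1 also carries the (4-chlorobenzyl)sulfanyl group, though on a differently arranged core, and its value is close to that of compound 2; both sit far below compound 3. The expectation is therefore a large step back toward stronger inhibition, roughly undoing a 20-fold higher number from compound 2 to compound 3 (1.29 log units; beyond the scatter). Compound 4 is estimated at 5000 nM, with a range from 1500 nM to 16000 nM, which means an expected step of a 20-fold lower number from compound 3 to compound 4 (1.29 log units; beyond the scatter).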

Compound 4, half-maximal inhibitory concentration: 3000 nM
Beside the measured number, compound 4's estimate is 1.7-fold (0.22 log units) above it; the range from low to high includes it.
By their numbers in this assay, from the lowest: compounds 1, 4 and 2 (each within the scatter of the next); then compound 3.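

In this assay, 4-chlorophenyl in place of 3-(trifluoromethyl)phenyl on a saturated chain carbon bound to a sulfur gives a 33-fold lower number from compound 3 to compound 4 (1.51 log units; beyond the scatter), so a substituted phenyl at this position can keep the number as low as that of the unsubstituted phenyl. Chloro in place of hydrogen on an aromatic carbon gives a 1.7-fold lower number from compound 2 to compound 4 (0.22 log units; within the scatter), which lies within the scatter and shows that the high number of compound 3 does not extend to every substituted phenyl here; among these compounds, only the 3-(trifluoromethyl)phenyl group stands apart. Methyl in place of hydrogen on an aromatic carbon gives no change at the digits printed from compound 1 to compound 4 (within the scatter), so with the (4-chlorobenzyl)sulfanyl group in place, this methyl leaves the number unchanged at the digits printed.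

As far as these compounds go, the step between compound 3 and compound 4 changes both the substituent and its place on the phenyl, so it remains open whether 3-chlorophenyl or 4-(trifluoromethyl)phenyl would sit with compound 4 or with compound 3. Nothing given here accounts for the high number of compound 3.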